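The source may hold more compounds than are shown below. What is called first, only, known or untested is meant among the compounds shown, and "the series" means these compounds.

In an ADME assay on CHO cells (Cricetulus griseus) for cytotoxicity (a higher number here means a weaker inhibitor, a lower number a stronger inhibitor), compound 1 `Nc1cc(Nc2cnccn2)nc(-c2ccnc(N3CCNCC3)c2)c1` gives > 20000 nM, which is a limit. Compound 2 `Oc1ccc(CNc2cc(Nc3cnccn3)nc(-c3ccnc(N4CCNCC4)c3)c2)cc1` gives > 20000 nM, also a limit. Compound 3 `c1cc(-c2cccc(Nc3cnccn3)n2)cc(N2CCNCC2)c1` gives > 15000 nM, again a limit. Compound 2 therefore has no exact value, and neither do the other two compounds. Compound 4 `O=C(Nc1cc(Nc2cnccn2)nc(-c2ccnc(N3CCNCC3)c2)c1)C1CCNCC1` has (piperidin-4-yl)carbonyl in place of 4-hydroxybenzyl on a nitrogen on an aromatic ring. For the measured compounds named here, the only measured change on that nitrogen is a step that the two limits leave unreadable from compound 1 to compound 2, so it offers no size or direction to carry over. No shift beyond the scatter is expected in this assay. The expected change is a number no higher from compound 2 to compound 4 (the limit leaves the size open). For compound 4, the estimate is 20000 nM, with an expected range of 8000 nM to 40000 nM.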

Compound 4, half-maximal inhibitory concentration: > 20000 nM
Compound 4 ended at the assay's limit (the forecaster's own chance of this, stated with the estimate: 75%); the middle value sits exactly at the limit.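

Compound 1, compound 2 and compound 4 all give only limits, so the steps among them cannot be read. The compounds shown leave open whether any change on that nitrogen shifts the read-out in this assay at all.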